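Ethyl for Methoxy on the Sulfonamide Aryl Ring

The source may hold more compounds than are shown below. What is called first, only, known or untested is meant among the compounds shown, and "the series" means these compounds.

Compound 1, `O=S(=O)(Nc1ccc2oc(-c3ccccc3)nc2c1)c1ccc(Cl)c(Cl)c1`, gives > 63000 nM in an assay on isolated protein for inhibition of malate dehydrogenase, mitochondrial (Sus scrofa), with stated times of 45 min and 30 min (a higher number here means a weaker inhibitor, a lower number a stronger inhibitor), which is a limit of the assay and not a number.
Compound 2, `COc1ccc(S(=O)(=O)Nc2ccc(-c3nc4ccccc4o3)cc2)cc1`, gives > 63000 nM in this assay, again a limit.
Compound 3, `Cc1ccccc1S(=O)(=O)Nc1ccc2oc(-c3ccccc3)nc2c1`, gives > 63000 nM in this assay, again a limit.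

Compound 2 therefore stands at the limit, where every value shown sits, as the limit of > 63000 nM in this assay, at which 3 of the 3 values shown sit, states. Going by the values given here, the only step between measured compounds, a step that the two limits leave unreadable from compound 1 to compound 3, puts 2-methylphenyl in place of 3,4-dichlorophenyl on a sulfonyl sulfur, and its size cannot be read because both ends are limits. Compound 4, `CCc1ccc(S(=O)(=O)Nc2ccc(-c3nc4ccccc4o3)cc2)cc1`, differs from compound 2 by ethyl in place of methoxy on an aromatic carbon. Among the compounds with values here, no measured step bears on an exchange of ethyl for methoxy on an aromatic carbon, so no direction can be read from the data. Given that all three compounds rest at the limit described by the limit of > 63000 nM in this assay, at which 3 of the 3 values shown sit, compound 4 is expected to remain there too, estimated at 100000 nM with a range of 30000 nM to 400000 nM. The step this estimate means, a step that the limit leaves unreadable from compound 2 to compound 4, is expected to be none beyond the usual scatter.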

Compound 4, half-maximal inhibitory concentration: > 63000 nM
Compound 4: no number, only a limit; the forecaster's own chance of this, stated with the estimate: 85%; the middle value does not contradict the limit.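

Compound 2 and compound 4 both rest at a limit of the assay, so no new step can be read between them. The compounds shown leave open which structure would give a measurable inhibition in this assay, with every value shown at one place: the limit of > 63000 nM in this assay, at which 4 of the 4 values shown sit.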